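The compounds below may be only part of what the source reports. "The series", "measured", "known", "first", "only" and "open" are said of these compounds alone.

Compound 2 `CC(C)(C)[Si](C)(C)O[C@H]1CCCO[C@@H]1CC=O` gives 40000 nM in a functional assay on HL-60 cells (Homo sapiens); a higher number here means a weaker inhibitor of growth, a lower number a stronger inhibitor of growth; of the two numbers in hand it sits at one end, yet its gap to compound 1 `CC(C)(C)[Si](C)(C)O[C@H]1CCCO[C@@H]1CCO`, which gives 46000 nM, is within the scatter, as the step of a 1.2-fold lower number from compound 1 to compound 2 (0.06 log units; within the scatter) shows. Compound 3 `COC(=O)/C=C/C[C@H]1OCCC[C@@H]1O[Si](C)(C)C(C)(C)C` differs from compound 2 by 2-(methoxycarbonyl)ethenyl in place of formyl on a saturated chain carbon bound to a saturated ring carbon. For the measured compounds named here, the single measured step touches the same place but exchanges other groups, so it bears only loosely here, and no change beyond the scatter is expected. Compound 3 is expected to shift by no change at the digits printed from compound 2 to compound 3 (within the scatter). The estimate for compound 3 in this assay is 40000 nM, with a range from 15000 nM to 100000 nM.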

Compound 3, concentration for 50% growth inhibition: 22000 nM
Estimate against measurement, compound 3: 1.8-fold (0.26 log units) above; measured number inside the range.
By their numbers in this assay, from the lowest: compounds 3, 2 and 1 (each within the scatter of the next, the first and the last beyond it).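

In this assay this position on a saturated chain carbon bound to a saturated ring carbon accepts the much longer 2-(methoxycarbonyl)ethenyl group in place of formyl, with a 1.8-fold lower number from compound 2 to compound 3 (0.26 log units; within the scatter). Against the hydroxymethyl group, the same position now gives the first step beyond the scatter, though a modest one, with a 2.1-fold lower number from compound 1 to compound 3 (0.32 log units; beyond the scatter). No measured evidence accounts for either step.

As far as these compounds go, it remains open whether a carboxylic acid in place of the methoxycarbonyl group would shift the number further. From the compounds shown here alone, the effect of an amine at this position also remains open.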